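The source may report more compounds than this note shows. Statements on the series, on what has been measured and on what is new or still open speak of the compounds shown alone.

Measured so far in an assay for binding affinity to 17-beta-hydroxysteroid dehydrogenase type 1 (Homo sapiens), with a stated time of 20 min, tested at 1 uM; on this read-out higher numbers stand for more inhibition at the one concentration tested (going by the name of the read-out) and lower numbers for less inhibition:
Compound 1 `COc1ccc(-c2ccc3c(O)cccc3c2)cc1` gives 28%.
Compound 2 `O=[N+]([O-])c1ccc(-c2ccc3c(O)cccc3c2)cc1` gives 15%.
Compound 3 `Oc1cccc2cc(-c3cncnc3)ccc12` gives < 10%, which is a limit of the assay and not a number.

Among the two numbers shown, compound 2 stands lowest; its nearest neighbour is compound 1, which in this assay gives 28%. The remaining value is a limit, (the limit of < 10% in this assay, at which 1 of the 3 values shown sits). Within the data shown here, the only measured step is a number 13 percentage points lower from compound 1 to compound 2 (beyond the scatter), with nitro in place of methoxy on an aromatic carbon.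

Compound 4 `CNS(=O)(=O)c1ccc(-c2ccc3c(O)cccc3c2)cc1` has not yet been measured in this assay. It differs from compound 2 in a single place: methylsulfamoyl in place of nitro on an aromatic carbon. Among the measured compounds shown here, no measured step puts a methylsulfamoyl group on that carbon, so the step from methoxy to nitro bears on it only loosely: it shows that exchanging the group on that carbon moved the read-out by a modest amount, beyond the scatter, but it gives no direction for the present exchange. With compound 2 already near the limit, a step within the scatter in either direction is the most that can be expected, and the estimated step is a number 3 percentage points higher from compound 2 to compound 4 (within the scatter). Compound 4 is therefore expected to give about 18%, within a range from 5% to 35%.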

Compound 4, a percentage reported as inhibition, at one concentration (the size of the read-out at that concentration, not a potency): 12%
Compound 4: the middle estimate sits 6 percentage points above what was measured; low and high end bracket the measured number.
By their numbers in this assay, from the lowest: compounds 4 and 2 (each within the scatter of the next); then compound 1. At a limit, below all of these: compound 3.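

In this assay, methylsulfamoyl and nitro on this aromatic carbon, para to a large group, cannot be told apart (a number 3 percentage points lower from compound 2 to compound 4 (within the scatter)). Methoxy on the same carbon stands apart from methylsulfamoyl as it does from nitro (a number 16 percentage points lower from compound 1 to compound 4 (beyond the scatter)), so among the three groups shown at this place, compound 1 keeps the highest number, and two quite different replacements both fall short of it. Neither the larger heavy-atom count nor the hydrogen-bond donor that enters with methylsulfamoyl separates compound 4 from compound 2 on this read-out, and the numbers of these two compounds stand close to a limit of the assay: the limit of < 10% in this assay, at which 1 of the 4 values shown sits.

Going by these compounds, it stays open whether a hydroxyl, an amine or a carboxylic acid on that carbon, or a longer chain in place of the methyl of methylsulfamoyl, would match or pass compound 1 at 28% in this assay. Since every number comes from one tested concentration, the compounds shown also leave open how far these differences would carry over to potency.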